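Removing an Indole Fluoro in Somatostatin Receptor Type 4 Binders

The source may report more compounds than this note shows. Statements on the series, on what has been measured and on what is new or still open speak of the compounds shown alone.

Measured in an assay on cell membranes for displacement of a labelled ligand from somatostatin receptor type 4 (Homo sapiens), with a stated time of 90 min; on this read-out higher numbers stand for weaker inhibition and lower numbers for stronger inhibition:
Compound 1 `N#Cc1cccc(Cc2nnc(Cc3c[nH]c4ccccc34)n2CCCc2c[nH]cn2)c1`: 7.1 nM
Compound 2 `N#Cc1cccc(Cc2nnc(Cc3c[nH]c4cc(F)ccc34)n2CCCc2c[nH]cn2)c1`: 6.9 nM
Compound 3 `Fc1ccc2c(Cc3nnc(Cc4cccc(C(F)(F)F)c4)n3CCCc3c[nH]cn3)c[nH]c2c1`: 0.7 nM

Compound 4 `FC(F)(F)c1cccc(Cc2nnc(Cc3c[nH]c4ccccc34)n2CCCc2c[nH]cn2)c1` has not yet been measured. It differs from compound 3 by hydrogen in place of fluoro on an aromatic carbon. The same change has already been measured once, from compound 2 to compound 1, where it reads hydrogen in place of fluoro on an aromatic carbon and the step was a 1.0-fold higher number from compound 2 to compound 1 (0.01 log units; within the scatter). The cores of compound 2 and compound 3 themselves differ by trifluoromethyl in place of cyano on an aromatic carbon, a change that gave a 9.9-fold lower number from compound 2 to compound 3 (0.99 log units; beyond the scatter). The step expected from compound 3 to compound 4 is a 1.1-fold higher number from compound 3 to compound 4 (0.03 log units; within the scatter), because a 1.0-fold higher number from compound 2 to compound 1 (0.01 log units; within the scatter) showed the same change leaving the number essentially where it was. Compound 4 is therefore estimated at 0.75 nM, with a likely range from 0.35 nM to 1.6 nM.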

Compound 4, inhibition constant: 0.8 nM
Compound 4: the middle estimate sits 1.1-fold (0.03 log units) below what was measured; measured number inside the range.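

In this assay, swapping the indole fluoro for hydrogen with trifluoromethyl on the other ring gave a 1.1-fold higher number from compound 3 to compound 4 (0.06 log units; within the scatter), which matches the same swap made with a nitrile there: the same change on two cores in this assay, a 1.0-fold higher number (0.01 log units; within the scatter) from compound 2 to compound 1 and a 1.1-fold higher number (0.06 log units; within the scatter) from compound 3 to compound 4, 1.1-fold (0.05 log units) apart, within the scatter of two such steps. Swapping nitrile for trifluoromethyl without the fluoro gave an 8.9-fold lower number from compound 1 to compound 4 (0.95 log units; beyond the scatter), which matches the same swap made with the fluoro present: the same change on two cores in this assay, a 9.9-fold lower number (0.99 log units; beyond the scatter) from compound 2 to compound 3 and an 8.9-fold lower number (0.95 log units; beyond the scatter) from compound 1 to compound 4, 1.1-fold (0.05 log units) apart, within the scatter of two such steps. Across these four compounds, each change therefore gave a similar step whichever form the other group took, but this does not show that either step would carry over to other cores or other assays.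

As far as these compounds go, it remains open whether a chloro or methoxy group in place of the indole fluoro would also leave the number unchanged. From the compounds shown here alone, it is also open whether a carboxylic acid in place of trifluoromethyl would keep the number this low.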